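From a Branched Chain to Methyl in Compound 3

This account rests on a few compounds, and the source may have more. Where it says the series, first, only, none or still open, it means among the compounds named here.

Measured in a functional assay for inhibition, with Rattus norvegicus as the target; a higher number here means a weaker inhibitor, a lower number a stronger inhibitor:
compound 1 `COc1ccc(Nc2c(NC(C)C(C)(C)C)c(=O)c2=O)cc1`: 2400 nM
compound 2 `CC(/N=c1\c(O)c(O)\c1=N/c1ccccc1C#N)C(C)(C)C`: > 30000 nM
compound 3 `CC(C)C(C)/N=c1\c(O)c(O)\c1=N/c1ccc(C#N)cc1`: 1900 nM

The entry for compound 2 is a limit of the assay and not a number. Going by the values given here, compound 3 stands at 1900 nM, within the scatter of compound 1, and these two compounds hold the only actual numbers in the set.

The next compound, compound 4 `C/N=c1\c(O)c(O)\c1=N/c1ccc(C#N)cc1`, has methyl in place of 1,2-dimethylpropyl on a double-bonded nitrogen. Among the compounds with values here, no pair of measured compounds differs in one place, so the data offer no direct precedent for this change. Nor has any compound with so small a group at this place been measured in this assay. A moderate step towards a higher number, beyond the scatter, is therefore expected, though with wide uncertainty. The estimated move is a 4.2-fold higher number from compound 3 to compound 4 (0.62 log units; beyond the scatter). Compound 4 is expected at about 8000 nM, with an estimated range of 1800 nM to 30000 nM.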

Compound 4, half-maximal inhibitory concentration: > 30000 nM
Compound 4 gave a limit, no number; the forecaster's own chance of this, stated with the estimate: 20%; at least 3.7-fold (0.57 log units) between middle value and limit.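

Going by these compounds alone, the change from 1,2-dimethylpropyl to methyl on a double-bonded nitrogen is the first single-place step in the set, and in this assay it gives an at least 15-fold higher number from compound 3 to compound 4 (1.19 log units; beyond the scatter). Compound 4 stands at > 30000 nM, which is a limit of the assay and not a number. On these data alone, the group at this place therefore matters: with the rest of compound 3 unchanged, methyl takes the value out of the measurable range, and the full size of the step stays unknown because the reading stops at the limit: the limit of > 30000 nM in this assay, at which 2 of the 4 values shown sit.

The compounds shown leave open whether an ethyl or propyl chain, or a cyclopentyl ring, at this place would keep a measurable value. They also do not tell whether methyl would have the same effect in the setting of compound 1.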